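Trifluoromethyl Replaces Methoxy on the Pendant Aromatic Ring

The source may report more compounds than this note shows. Statements on the series, on what has been measured and on what is new or still open speak of the compounds shown alone.

Compound 2 `COc1ccc(-c2nn(-c3nc(C(=O)O)cs3)c3ccccc23)cc1` holds the lowest of the two numbers recorded so far in an assay on isolated protein for antagonist activity at prostaglandin E2 receptor EP1 subtype (Homo sapiens), read by reporter gene assay (a higher number here means a weaker inhibitor, a lower number a stronger inhibitor), where compound 2 gives 4 nM. Its nearest neighbour is compound 1 `O=C(O)c1csc(-n2nc(-c3ccc(Cl)cc3)c3ccccc32)n1`, which in this assay gives 12 nM. Among the measured compounds shown here, the only measured step, a 3.0-fold lower number from compound 1 to compound 2 (0.48 log units; beyond the scatter), arose from a methoxy in place of chloro on an aromatic carbon, and it counts as modest. Compound 3 `O=C(O)c1csc(-n2nc(-c3ccc(C(F)(F)F)cc3)c3ccccc32)n1` has not yet been measured; it differs from compound 2 by trifluoromethyl in place of methoxy on an aromatic carbon. The measured step bears on this change because a 3.0-fold lower number from compound 1 to compound 2 (0.48 log units; beyond the scatter) was produced at the same aromatic carbon, so a shift of similar size seems plausible here too. Trifluoromethyl is neither chloro nor methoxy, so the direction is not fixed by the data. Compound 2 carries the methoxy that gave the lowest number, which argues for a modest rise from it. Compound 3 is therefore expected to move by a 2.5-fold higher number from compound 2 to compound 3 (0.40 log units; beyond the scatter). Compound 3 is estimated at 10 nM, with a likely range from 3 nM to 35 nM.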

Compound 3, half-maximal inhibitory concentration: 140 nM
Compound 3: middle estimate off by 14-fold (1.15 log units), on the low side, and the stated range ends below it.
By their numbers in this assay, from the lowest: compound 2; then compound 1; then compound 3.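

This position proved far more sensitive than the first pair of compounds had shown: in this assay, trifluoromethyl in place of methoxy gave a 35-fold higher number from compound 2 to compound 3 (1.54 log units; beyond the scatter) and counts as large, whereas the earlier change at the same aromatic carbon was modest. Nor does the rise depend on methoxy as the point of comparison, since trifluoromethyl in place of chloro gave a 12-fold higher number from compound 1 to compound 3 (1.07 log units; beyond the scatter) and also counts as large. Compound 3 thus has the highest number of the three, and the group on this carbon, para to a large group, can move the number much further than the first step revealed; nothing measured on these compounds accounts for the size of this rise.

As far as these compounds go, three groups on a single carbon give no rule, so it stays open whether fluoro, ethoxy, hydroxyl, an amine or a nitrile there would sit nearer to methoxy or to trifluoromethyl. From the compounds shown here alone, it is also open whether the same order of the three groups would hold if the carboxylic acid of the shared core gave way to a tetrazole or an amide.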